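Nitrile in Place of Amidoxime: Expected Cytotoxicity

A few compounds are considered here, and "the series" means these few. Any claim that something is new, unique, unknown or untested is made for them only; others in the source may bear on it.

Measured so far in an ADME assay on HeLa cells (Homo sapiens) for cytotoxicity, read by ATP content, with a stated time of 3 days; on this read-out higher numbers stand for lower toxicity in this test and lower numbers for higher toxicity in this test:
compound 1 `N=C(CCCn1c(Cn2c(=O)n(C3CC3)c3ccncc32)cc2cc(Cl)ccc21)NO` gives > 50000 nM, a limit of the test and not a number.
compound 2 `CC(C)CCn1c(Cn2c(=O)n(C3CC3)c3ccncc32)nc2ncccc21` gives > 100000 nM, likewise a limit.
compound 3 `O=c1n(Cc2cc3ccncc3n2CCCCO)c2cnccc2n1C1CC1` gives > 100000 nM, likewise a limit.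

Compound 1 sits at the limit of > 50000 nM in this assay, at which 1 of the 3 values shown sits. The other two compounds share (the limit of > 100000 nM in this assay, at which 2 of the 3 values shown sit). Going by the values given here, all three are limits, so no measured step between any pair exists, and compound 1 cannot be ranked against the others. Compound 4 `N#CCCCn1c(Cn2c(=O)n(C3CC3)c3ccncc32)cc2cc(Cl)ccc21` differs from compound 1 by a group of 2 heavy atoms (1 carbon, 1 nitrogen; no ring) in place of a group of 4 heavy atoms (1 carbon, 2 nitrogen, 1 oxygen; no ring), on a saturated chain carbon, three bonds along the chain from an aromatic nitrogen. Among the compounds with values here, no measured step shows the effect of such a change, so in this assay the estimated step that the limit leaves unreadable from compound 1 to compound 4 is expected to stay within the usual scatter. Compound 4 is expected to give 80000 nM, within 30000 nM to 200000 nM, and most likely again only as a limit.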

Compound 4, half-maximal cytotoxic concentration: > 50000 nM
Compound 4: a limit, no number; the forecaster's own chance of this, stated with the estimate: 85%; the middle value is on the limit's open side.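

Going by these compounds alone, compound 1 and compound 4 both give only a limit of the test, so no step between them can be read. The compounds shown leave open whether the cyano group changes the result in this assay at all.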